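Swapping hepta-1,3-dien-1-yl for 2-(4-cyanophenyl)ethynyl

The compounds below may be only part of what the source reports. "The series", "measured", "known", "first", "only" and "open" are said of these compounds alone.

In a functional assay on NIH3T3 cells (Mus musculus) (on this read-out higher numbers stand for an effect only at larger amounts of compound and lower numbers for an effect already at smaller amounts), compound 1 `Cn1cncc1C(OCc1ccc(C#N)cc1C#Cc1ccccn1)c1ccc(C#N)cc1` has only a limit, > 0.1 nM. Going by the values given here, compound 2 `CCC/C=C/C=C/c1cc(C#N)ccc1COC(c1ccc(C#N)cc1)c1cncn1C` gives 16.7 nM, the only true number so far. Compound 3 `Cn1cncc1C(OCc1ccc(C#N)cc1C#Cc1ccc(C#N)cc1)c1ccc(C#N)cc1` carries 2-(4-cyanophenyl)ethynyl in place of hepta-1,3-dien-1-yl on an aromatic carbon. Among the compounds with values here, the one measured step that bears on this change is a step that the limit leaves unreadable from compound 1 to compound 2, which swaps the same chain for a related ethynyl group. It offers neither a size nor a direction, so no clear shift is expected. The estimated step is a 1.0-fold higher number from compound 2 to compound 3 (0.01 log units; within the scatter). Compound 3 is expected at 17 nM, within an estimated range of 3 nM to 90 nM.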

Compound 3, half-maximal effective concentration: 11.6 nM
Compound 3: the middle estimate sits 1.5-fold (0.17 log units) above what was measured; the range from low to high includes it.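

The step in this assay is a 1.4-fold lower number from compound 2 to compound 3 (0.16 log units; within the scatter). At this place, on an aromatic carbon meta to a cyano group, an open chain without a ring and a group carrying an aromatic ring therefore give values within the scatter of each other. Compound 1 has only a limit, > 0.1 nM, so the steps from it, including 4-cyanophenyl in place of pyridin-2-yl, cannot be read.

Open, from the compounds shown here alone, is whether an amine or a carboxylic acid at this place would leave the number where it stands. A chain shorter than hepta-1,3-dien-1-yl raises the same question.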